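The source may report more compounds than this note shows. Statements on the series, on what has been measured and on what is new or still open speak of the compounds shown alone.

Measured in a physicochemical assay for solubility, read by HPLC, in phosphate buffer, measured as kinetic solubility, at pH 7.4; a higher number here means a more soluble compound, a lower number a less soluble compound:
- Compound 1 `CCC(=O)c1cc(-c2ccc(Cl)cc2)n(-c2ccc(S(N)(=O)=O)cc2)c1` gives 19500 nM
- Compound 2 `CCC(=O)c1cc(-c2ccc(F)cc2)n(-c2ccc(S(N)(=O)=O)cc2)c1C` gives 29300 nM
- Compound 3 `CCC(=O)c1cc(-c2ccc(C)cc2)n(-c2ccc(S(N)(=O)=O)cc2)c1C` gives 1000 nM

Compound 2 stands within the scatter of compound 1 and far from compound 3. Compound 4 `CCC(=O)c1cc(-c2ccc(F)cc2)n(-c2ccc(S(N)(=O)=O)cc2)c1` differs from compound 2 by one change, hydrogen in place of methyl on an aromatic carbon. Among the compounds with values here, the one measured step of a 29-fold lower number from compound 2 to compound 3 (1.47 log units; beyond the scatter) is large, but it sits on the 4-fluorophenyl group and not at this carbon, so it offers little guidance here. Within the data shown here, no measured step removes this methyl alone. Compound 1 also lacks the methyl but carries chloro instead of fluoro, and it gives 19500 nM. No step beyond the scatter is therefore expected in this assay. The estimated step is a 1.2-fold lower number from compound 2 to compound 4 (0.07 log units; within the scatter). Compound 4 is expected at 25000 nM, with an estimated range from 11000 nM to 60000 nM.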

Compound 4, solubility: 63000 nM
Compound 4: the middle estimate sits 2.5-fold (0.40 log units) below what was measured; measured number above the stated range.
By their numbers in this assay, from the lowest: compound 3; then compounds 1 and 2 (each within the scatter of the next); then compound 4.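

Hydrogen in place of methyl on this aromatic carbon now has a measured step of its own in this assay: a 2.2-fold higher number from compound 2 to compound 4 (0.33 log units; beyond the scatter). Fluoro in place of chloro on an aromatic carbon, with no methyl present, also has one: a 3.2-fold higher number from compound 1 to compound 4 (0.51 log units; beyond the scatter). Both steps are modest and lie beyond the scatter, but nothing measured here explains either one. Still open, from the compounds shown here alone, is how an ethyl group or an amine at this carbon would compare with hydrogen and methyl. Also open, going by these compounds, is whether the methyl step would hold with chloro in place of fluoro.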